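Compound 4 in the thallium-flux series: trifluoromethyl to cyano

A few compounds are considered here, and "the series" means these few. Any claim that something is new, unique, unknown or untested is made for them only; others in the source may bear on it.

Compounds measured so far:
compound 1 `Cc1cc(NC(=O)Cn2nnc(-c3ccc(Cl)c(Cl)c3)n2)n(C2CCCCC2)n1` — 1220 nM
compound 2 `COc1ccc(-c2nnn(CC(=O)Nc3cc(C)nn3C3CCCCC3)n2)cc1` — 175 nM
compound 3 `Cc1cc(NC(=O)Cn2nnc(-c3cccc(C(F)(F)F)c3)n2)n(C2CCCCC2)n1` — 183 nM

In an assay on HEK293 cells for activation of Kir3.1/Kir3.2 (Homo sapiens), read by thallium flux (a lower number here means that less compound is needed, a higher number that more compound is needed for the effect), compound 3 gives 183 nM, which places it second highest of the three numbers, though its gap to compound 2 is within the scatter, and only compound 1 is separated from it beyond the scatter. Compound 4 `Cc1cc(NC(=O)Cn2nnc(-c3cccc(C#N)c3)n2)n(C2CCCCC2)n1` differs from compound 3 in one place: cyano in place of trifluoromethyl on an aromatic carbon. Among the measured compounds shown here, no measured pair shows this exact exchange. For the measured compounds named here, the steps that bear on it are the two changes at the same aryl group: a 6.7-fold lower number from compound 1 to compound 3 (0.82 log units; beyond the scatter) and a 1.0-fold higher number from compound 2 to compound 3 (0.02 log units; within the scatter). They show that exchanging the substituent on this ring can move the number moderately or leave it unchanged; the two substituents that sit close to compound 3 in the numbers, compound 2 among them, suggest little movement. The step of a 1.4-fold higher number from compound 3 to compound 4 (0.14 log units; within the scatter) is therefore expected to stay within the scatter. Compound 4 is estimated at 250 nM in this assay, with a range of 80 nM to 800 nM.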

Compound 4, half-maximal effective concentration: 183 nM
The estimate for compound 4 lay 1.4-fold (0.14 log units) above the measured number, within the range that was stated.
By their numbers in this assay, from the lowest: compounds 2, 3 and 4 (each within the scatter of the next); then compound 1.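

In this assay, the exchange of trifluoromethyl for cyano on this aromatic carbon gives no change at the digits printed from compound 3 to compound 4 (within the scatter), although the entering group has fewer heavy atoms and brings a hydrogen-bond acceptor that the leaving group lacks. The 3-cyanophenyl group also gives a 1.0-fold higher number from compound 2 to compound 4 (0.02 log units; within the scatter), while a 6.7-fold lower number from compound 1 to compound 4 (0.82 log units; beyond the scatter) shows that, among the four compounds, only the 3,4-dichlorophenyl group of compound 1 stands apart from the other three aryl groups. Nothing measured here explains why these three aryl groups cannot be told apart or why compound 1 differs.

On these data alone, it remains open whether an amine, a carboxylic acid or a single chlorine on this ring would stay with compounds 2, 3 and 4 or move towards compound 1. As far as these compounds go, the rest of the core is the same in all four compounds, so the effect of any change there also remains open.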